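Methoxy-to-fluoro exchange on the pendant aryl ring

The compounds below may be only part of what the source reports. "The series", "measured", "known", "first", "only" and "open" are said of these compounds alone.

Compound 1 `COc1ccccc1-c1oc2ccc(NC(C)=O)cc2c(=O)c1O` and compound 2 `CC(=O)Nc1ccc2oc(-c3ccccc3F)c(O)c(=O)c2c1` share one core and differ only on the aromatic ring attached to it. In an ADME assay on MT4 cells (Homo sapiens) for cytotoxicity, read by MTT assay, with a stated time of 4 days (a higher number here means that more compound is tolerated, a lower number that less compound is tolerated), compound 1 gives 385000 nM, and compound 2 gives 171000 nM. The change fluoro in place of methoxy on an aromatic carbon produced a 2.3-fold lower number from compound 1 to compound 2 (0.35 log units; beyond the scatter), a step that lies beyond the scatter.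

Compound 3 `COc1cccc(-c2oc3ccc(N)cc3c(=O)c2O)c1` carries a different core; the difference between the two cores is not broken down here. In this assay compound 3 gives 40800 nM, the lowest of the three numbers, with compound 2 nearest to it and compound 1 furthest from it, both gaps beyond the scatter.

Compound 4 `Nc1ccc2oc(-c3cccc(F)c3)c(O)c(=O)c2c1` has not yet been measured and is related to compound 3 by fluoro in place of methoxy on an aromatic carbon. Within the data shown here, this is the same kind of change as the one from compound 1 to compound 2, not the same change: in compound 1 the group sits on an aromatic carbon ortho to a large group, whereas in compound 3 it sits meta to a large group. Among the measured compounds shown here, the single precedent is a 2.3-fold lower number from compound 1 to compound 2 (0.35 log units; beyond the scatter), and it points to a lower number. For compound 4 the expected step in this assay is a 1.9-fold lower number from compound 3 to compound 4 (0.27 log units; within the scatter), set close to the earlier step; the range is kept wide, as the place of the exchange differs.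

Compound 4 is estimated at 22000 nM in this assay, expected to fall between 9000 nM and 55000 nM.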

Compound 4, half-maximal cytotoxic concentration: 35300 nM
Compound 4: the middle estimate sits 1.6-fold (0.21 log units) below what was measured; the range from low to high includes it.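

In this assay, fluoro in place of methoxy on an aromatic carbon of the pendant ring, meta to a large group, gives a 1.2-fold lower number from compound 3 to compound 4 (0.06 log units; within the scatter), so the two groups are not told apart at this place on this core. Set beside the earlier exchange, the new step gives no sign that the outcome depends on the core: the same change on two cores in this assay, a 2.3-fold lower number (0.35 log units; beyond the scatter) from compound 1 to compound 2 and a 1.2-fold lower number (0.06 log units; within the scatter) from compound 3 to compound 4, 1.9-fold (0.29 log units) apart, within the scatter of two such steps. Among these compounds, this does not show that the change carries over unaltered, since the earlier step lies beyond the scatter and the new one within it, there are only two pairs, and the pairs differ in the place of the exchange on the pendant ring as well as in the core, so the two influences cannot be separated.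

The compounds shown leave open whether the step follows the core or the place, which the same exchange at one shared place on both cores would settle. They also leave open how a chloro or a trifluoromethyl group at these places would compare with fluoro and methoxy in this measure of tolerance.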